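The source may hold more compounds than are shown below. What is called first, only, known or untested is meant among the compounds shown, and "the series" means these compounds.

Measured in an assay on HEK293 cells for positive allosteric modulation of metabotropic glutamate receptor 2 (Rattus norvegicus), read by thallium flux, with a stated time of 2.5 min; on this read-out lower numbers stand for smaller maximal responses and higher numbers for larger maximal responses:

compound 1 `CCCC(=O)c1ccc(OCCCCOc2cccc(C(=O)O)c2C)c(C)c1O`: 82.4%
compound 2 `Cc1c(OCCCCOc2ccc(C(=O)C(C)C)c(O)c2C)cccc1C(=O)O`: 66.9%
compound 3 `CCCC(=O)c1ccc(OCCCCOc2ccc(C(=O)O)cc2C)c(C)c1O`: 79.3%

Compound 1 and compound 2 share a core and differ by one change, (isopropyl in place of propyl on a carbonyl carbon). That change gave a number 15.5 percentage points lower from compound 1 to compound 2 (beyond the scatter). Compound 3 carries a different core; how the core of compound 3 differs from the core of compound 1 is not broken down here. Compound 3 and compound 1 lie within the scatter of each other in this assay, while compound 3 stands beyond the scatter from compound 2.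

Compound 4 `Cc1cc(C(=O)O)ccc1OCCCCOc1ccc(C(=O)C(C)C)c(O)c1C` is not yet measured. Among the compounds with values here, its relation to compound 3 is isopropyl in place of propyl on a carbonyl carbon, the same change as the one from compound 1 to compound 2, made at the same place. The expectation for compound 4 rests on one earlier step only, the drop recorded as a number 15.5 percentage points lower from compound 1 to compound 2 (beyond the scatter), carried onto the core of compound 3. On that basis a step of about a number 15.3 percentage points lower from compound 3 to compound 4 (beyond the scatter) is expected in this assay, so compound 4 is estimated to reach 64%, with a range from 52% to 76%.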

Compound 4, largest response reached (reported as percent of maximum), in percent of the reference or control that the assay uses: 76.9%
Estimate against measurement, compound 4: 12.9 percentage points below; the measured number lies above the stated range.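

In this assay, isopropyl in place of propyl on a carbonyl carbon gives a number 2.4 percentage points lower from compound 3 to compound 4 (within the scatter), and this step cannot be told apart from the earlier one on the core of compound 1: the same change on two cores in this assay, a number 15.5 percentage points lower (beyond the scatter) from compound 1 to compound 2 and a number 2.4 percentage points lower (within the scatter) from compound 3 to compound 4, 13.1 percentage points apart, within the scatter of two such steps. Within the data shown here, the data therefore give no ground for saying that the change behaves differently on the two cores, although only the step on the core of compound 1 lies beyond the scatter. With a single pair on each core, they also do not show that a common drop carries over, nor how large such a step would be on either core.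

From the compounds shown here alone, whether a tert-butyl group or a longer chain on that carbonyl carbon would separate the two cores remains open. Also open, going by these compounds, is how the same change would behave with an amide in place of the carboxylic acid.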